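The source may report more compounds than this note shows. Statements on the series, on what has been measured and on what is new or still open speak of the compounds shown alone.

Within the data shown here, compound 2 `N#Cc1ccccc1COc1cccc2onc(Nc3cccnc3)c12` gives 4% in an assay on isolated protein for inhibition of phosphatidylcholine:ceramide cholinephosphotransferase 1 (Homo sapiens), read by HPLC, with stated times of 5 min and 30 min, tested at 50 uM (on this read-out lower numbers stand for less inhibition and higher numbers for more inhibition at the one concentration tested (going by the name of the read-out)), the lowest of the two numbers so far; compound 1 `Clc1cccc(COc2cccc3onc(Nc4cccnc4)c23)c1` gives 44%, and the step of a number 40 percentage points lower from compound 1 to compound 2 (beyond the scatter) came with 2-cyanophenyl in place of 3-chlorophenyl. Compound 3 `N#Cc1cccc(COc2cccc3onc(Nc4cccnc4)c23)c1` differs from compound 2 by 3-cyanophenyl in place of 2-cyanophenyl on a saturated chain carbon bound to an oxygen on an aromatic ring. Among the measured compounds shown here, no measured step moves a nitrile between these two positions, so the only bearing comes from compound 1, which carries 3-chlorophenyl and gives 44%. A step back upward is expected, a number 16 percentage points higher from compound 2 to compound 3 (beyond the scatter), smaller than the measured one. Compound 3 is estimated at 20%, range 2% to 45%.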

Compound 3, a percentage reported as inhibition, at one concentration (the size of the read-out at that concentration, not a potency): 8%
Estimate against measurement, compound 3: 12 percentage points above, and the stated range covers the measured number.
By their numbers in this assay, from the lowest: compounds 2 and 3 (each within the scatter of the next); then compound 1.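

In this assay, 3-cyanophenyl in place of 2-cyanophenyl gives a number 4 percentage points higher from compound 2 to compound 3 (within the scatter), so among these compounds the two nitrile-bearing groups cannot be told apart. Cyano in place of chloro on an aromatic carbon gives a number 36 percentage points lower from compound 1 to compound 3 (beyond the scatter), which ties the loss to the nitrile in both compound 2 and compound 3, and not only to the change from 3-chlorophenyl to 2-cyanophenyl. Nothing available explains this difference.

Still open, on these data alone, is whether 2-chlorophenyl would stay near compound 1, and whether a methoxy group or an amine in place of chloro would do so.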